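The source may report more compounds than this note shows. Statements on the series, on what has been measured and on what is new or still open speak of the compounds shown alone.

The shared core appears in compound 1 `C[C@H](NC1=NS(=O)(=O)c2cccnc2N1)C1CCCCC1`, compound 2 `C[C@@H](NC1=NS(=O)(=O)c2cccnc2N1)C1CCCCC1` and compound 3 `C[C@@H](NC1=NS(=O)(=O)c2cccnc2N1)c1ccccc1`. In a functional assay (ileum) for inhibition, with Cavia porcellus as the target (on this read-out lower numbers stand for an effect already at smaller amounts and higher numbers for an effect only at larger amounts of compound), compound 1 returns only a limit of > 300 uM. Compound 2 likewise returns a limit of > 300 uM. Compound 3 also returns a limit of > 300 uM. The step that the two limits leave unreadable from compound 1 to compound 2 stays unreadable because the limit of > 300 uM in this assay, at which 3 of the 3 values shown sit, masks any size, even though the fact that compounds 1 and 2 differ only in the configuration as drawn marks it as the smallest possible structural difference. The step that the two limits leave unreadable from compound 2 to compound 3 is unreadable for the same reason. Compound 2 therefore stands at a limit, and the two further values around it are limits as well.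

Compound 4 `C[C@@H](NC1=NS(=O)(=O)c2cc(Cl)cnc2N1)C1CCCCC1` differs from compound 2 by chloro in place of hydrogen on an aromatic carbon. Going by the values given here, no measured step gives a readable size, so the only guidance is that all three values sit at the limit. Compound 4 is therefore expected to give about 300 uM, within a range from 100 uM to 1000 uM. The expected step of a number no higher from compound 2 to compound 4 (the limit leaves the size open) is estimated to be none beyond the scatter, with a limit again the most probable outcome.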

Compound 4, concentration for half-maximal effect: 13.6 uM
The estimate for compound 4 lay 22-fold (1.34 log units) above the measured number; the whole stated range lies above it.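

In this assay, going by these compounds alone, chloro in place of hydrogen on the aromatic carbon two atoms from the ring nitrogen gives an at least 22-fold lower number from compound 2 to compound 4 (1.34 log units; beyond the scatter) and brings the first readable number to the series. Within the data shown here, none of the earlier steps can be read, because those compounds share one limit: the limit of > 300 uM in this assay, at which 3 of the 4 values shown sit. A single chlorine at this position is therefore enough to bring the read-out off that limit, which neither change on the chain had shown.

As far as these compounds go, whether bromo, methyl or methoxy on the same aromatic carbon would have a similar effect remains open. It is also open whether the configuration at the chain carbon, or phenyl in place of cyclohexyl, matters once chloro is present, since compound 4 is the only chloro compound shown.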